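The source may hold more compounds than are shown below. What is called first, only, known or untested is meant among the compounds shown, and "the series" means these compounds.

Compound 1 `Oc1cc(-c2ccc(Cl)cc2)nc2ncccc12` is the starting point; in a functional assay on SF-295 cells (Homo sapiens) (a lower number here means a stronger inhibitor of growth, a higher number a weaker inhibitor of growth), compound 1 gives 40700 nM. Compound 2 `Cc1cnc2nc(-c3ccc(Cl)cc3)cc(O)c2c1` differs from it in one place (methyl in place of hydrogen on an aromatic carbon), and in this assay compound 2 gives 2400 nM; this single change made a large step: a 17-fold lower number from compound 1 to compound 2 (1.23 log units; beyond the scatter). Compound 3 `COc1ccccc1-c1cc(O)c2cccnc2n1` carries a different core; how the two cores differ is not broken down here. In this assay, going by the values given here, compound 3 gives 23400 nM; this number and the one of compound 1, 40700 nM, lie within the usual scatter of each other. Compound 4 `COc1ccccc1-c1cc(O)c2c(C)ccnc2n1` is not yet measured; it differs from compound 3 by methyl in place of hydrogen on an aromatic carbon. Among the compounds with values here, this is the same kind of change as the one from compound 1 to compound 2, but the place is not the same: there the methyl sits two atoms from the ring nitrogen, meta to a fused ring and para to a fused ring, whereas here it sits ortho to a fused ring, meta to a fused ring and opposite the ring nitrogen. Within the data shown here, because the one measured example of this change, a 17-fold lower number from compound 1 to compound 2 (1.23 log units; beyond the scatter), was large, a gain is expected for compound 4 too, but a smaller one, since the methyl sits elsewhere; the expected step is a 2.9-fold lower number from compound 3 to compound 4 (0.47 log units; beyond the scatter). Compound 4 is therefore estimated at 8000 nM, with a plausible range from 2500 nM to 25000 nM.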

Compound 4, concentration for 50% growth inhibition: 23400 nM
Compound 4: the middle estimate sits 2.9-fold (0.47 log units) below what was measured; the range from low to high includes it.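

In this assay the methyl brings no change at the digits printed from compound 3 to compound 4 (within the scatter), so the gain seen on the core of compound 1 does not carry over automatically to the core of compound 3, and the two steps clearly differ: the same change on two cores in this assay, a 17-fold lower number (1.23 log units; beyond the scatter) from compound 1 to compound 2 and no change at the digits printed (within the scatter) from compound 3 to compound 4, 17-fold (1.23 log units) apart, beyond the scatter of two such steps

This does not show why they differ: the methyl sits at a different place in each pair and the rest of the molecule also differs, so the effect of place cannot be separated from that of the core. Two pairs also make no rule for the whole series.

Going by these compounds, it remains open whether a methyl at the place it holds in compound 2 would bring a gain on the core of compound 3. How an ethyl group or an amine would behave at either place is also left open.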